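Replacing 3-Carboxypropyl with a Dimethylcarbamoyl Cyclopropyl Group

This account rests on a few compounds, and the source may have more. Where it says the series, first, only, none or still open, it means among the compounds named here.

Compound 1 `Cc1nc(-c2ccc(C(F)(F)F)cc2)sc1CNc1ccc(CCCC(=O)O)cc1` — 44%
Compound 2 `CNC(=O)CCc1ccc(NCc2cccc(Oc3ccccc3)c2)cc1` — 67%

Of the compounds shown here, two have been measured in a functional assay on CHO cells for agonist activity at Free fatty acid receptor 1 (Homo sapiens), read by a luciferase reporter; a higher number here means a larger maximal response, a lower number a smaller maximal response. Compound 1 gives 44%, the lower of the two numbers. Compound 2, with a methylamide-ended chain and a phenoxy-substituted benzylamine, gives 67%, a figure beyond the scatter above that of compound 1. Going by the values given here, no pair of measured compounds differs in only one place, so no single step can be read from the data.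

Compound 3 `Cc1nc(-c2ccc(C(F)(F)F)cc2)sc1CNc1ccc([C@H]2C[C@@H]2C(=O)N(C)C)cc1` has not yet been measured. It differs from compound 1 in one place: 2-(dimethylcarbamoyl)cyclopropyl in place of 3-carboxypropyl on an aromatic carbon.

Among the compounds with values here, the shift from an acid-terminated chain to a dimethylcarbamoyl cyclopropyl group is of a size for which no direct precedent exists here; the only hint is that the amide-bearing compound 2 gives the higher of the two values. The step of a number 8 percentage points higher from compound 1 to compound 3 (within the scatter) is expected to be modest and upward, though a change within the scatter cannot be excluded. Compound 3 is therefore estimated at 52%, with a likely range from 28% to 78%.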

Compound 3, largest response reached (reported as percent of maximum), in percent of the reference or control that the assay uses: 49%
For compound 3 the middle estimate is 3 percentage points above the measured one; low and high end bracket the measured number.
By their numbers in this assay, from the lowest: compounds 1 and 3 (each within the scatter of the next); then compound 2.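

Going by these compounds alone, the change from 3-carboxypropyl to 2-(dimethylcarbamoyl)cyclopropyl is the first single step that can be read in this set, and in this assay it amounts to a number 5 percentage points higher from compound 1 to compound 3 (within the scatter). On this aromatic carbon, para to a large group, an open chain with one hydrogen-bond donor can thus give way to a group with a three-membered ring, two defined stereocentres and no hydrogen-bond donor, without a change in maximal response that stands out from the scatter. No measurement shown here explains this result.

The step alters the ring, the chain and the end group at once, so it leaves open which of these matters: a cyclopropyl group carrying a carboxylic acid, or an open chain ending in a dimethylamide, would separate them, and the opposite stereoisomers of the cyclopropyl group would show whether the defined arrangement counts. Within the data shown here, compound 2 differs from both compound 1 and compound 3 in more than one place, so no step to it can be read, and whether its methylamide-ended chain would behave the same way on the core of compound 1 remains open.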